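Chloro to Methylsulfanyl: A Step Without Direct Precedent

The source may hold more compounds than are shown below. What is called first, only, known or untested is meant among the compounds shown, and "the series" means these compounds.

Of the compounds shown here, three built on one shared core have been tested in a functional assay for inhibition of sodium/hydrogen exchanger (Oryctolagus cuniculus); a lower number here means a stronger inhibitor, a higher number a weaker inhibitor. Compound 1 `Cc1cc(Cl)c(S(C)(=O)=O)cc1C(=O)N=C(N)N` gives 25 nM in this assay, the lowest of the three numbers. Compound 2 `CS(=O)(=O)c1cc(C(=O)N=C(N)N)c(Cl)cc1Cl` gives 140 nM in this assay, and compound 3 `Cc1c(C(=O)N=C(N)N)ccc(Cl)c1S(C)(=O)=O` gives 1300 nM in this assay, so compound 1 stands below both by margins beyond the usual scatter. Going by the values given here, the one single-point step among them is a 5.6-fold higher number from compound 1 to compound 2 (0.75 log units; beyond the scatter), which shows chloro in place of methyl on an aromatic carbon weakening inhibition modestly.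

Compound 4 `CSc1cc(C)c(C(=O)N=C(N)N)cc1S(C)(=O)=O` is the next to be measured. It differs from compound 1 in one place: methylsulfanyl in place of chloro on an aromatic carbon. Among the compounds with values here, no measured step covers this exchange. The step from compound 1 to compound 2 concerns a different aromatic carbon and a different pair of groups, and compound 3 differs from compound 1 in the placement of several groups at once, so it offers no single-point comparison either. With only indirect guidance, the expectation is that the entering methylsulfanyl, ortho to a methylsulfonyl group, changes the number by at most a modest amount, more likely upward than downward. Compound 4 is therefore estimated at 50 nM in this assay, with a range from 15 nM to 200 nM. This estimate means an expected 2.0-fold higher number from compound 1 to compound 4 (0.30 log units; within the scatter).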

Compound 4, half-maximal inhibitory concentration: 6 nM
Estimate against measurement, compound 4: 8.3-fold (0.92 log units) above; measured number outside the range, below it.
By their numbers in this assay, from the lowest: compound 4; then compound 1; then compound 2; then compound 3.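

In this assay, each earlier compound carried a chloro ortho to its methylsulfonyl group, so those compounds could not show what this carbon does with any other group. Methylsulfanyl in place of chloro now gives a 4.2-fold lower number from compound 1 to compound 4 (0.62 log units; beyond the scatter), which shows that chloro is not needed here for a low number on this core, and that the exchange strengthens inhibition modestly. The change runs in the opposite direction to a 5.6-fold higher number from compound 1 to compound 2 (0.75 log units; beyond the scatter), which is of modest size too but concerns a different aromatic carbon and a different pair of groups, and no measurement available here explains why methylsulfanyl lowers the number.

What the compounds shown leave open is whether the lower number depends on the sulfur of methylsulfanyl, or would also appear with methoxy, an amine such as dimethylamino, or a longer chain such as ethylsulfanyl on this carbon. Also open, as far as these compounds go, is whether the same exchange of chloro for methylsulfanyl would lower the number on the core of compound 2, which has chloro in place of the methyl of compound 1.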